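Aryloxy acetamide series: the step from compound 2 to compound 4

The source may report more compounds than this note shows. Statements on the series, on what has been measured and on what is new or still open speak of the compounds shown alone.

In a functional assay on PC-12 cells (Rattus norvegicus) for cytotoxicity, read by MTT assay, with a stated time of 24 h, tested at 0.1 uM (a higher number here means a stronger effect of the compound at the concentration tested, a lower number a weaker effect), compound 1 `COc1ccc(C(c2ccc(OC)cc2)N2CCN(C(=O)COc3ccc4ccccc4c3)CC2)cc1` gives 2.55%. Compound 2 `COc1ccc(C(c2ccc(OC)cc2)N2CCN(C(=O)COc3ccccc3C)CC2)cc1` gives 2.45% and compound 3 `COc1ccc(OCC(=O)N2CCN(C(c3ccc(F)cc3)c3ccc(F)cc3)CC2)cc1` gives 3.1%. Compound 2 stands at the lowest of the three numbers, with compound 1 nearest and compound 3 furthest, yet all three values lie within the scatter of one another. Among the compounds with values here, the one step recorded between measured compounds, a number 0.1 percentage points lower from compound 1 to compound 2 (within the scatter), is also within the scatter.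

Compound 4 `COc1ccc(OCC(=O)N2CCN(C(c3ccc(OC)cc3)c3ccc(OC)cc3)CC2)cc1` is not yet measured. It differs from compound 2 by 4-methoxyphenyl in place of 2-methylphenyl on an oxygen on a saturated carbon. Within the data shown here, no measured pair shows this exact exchange. Among the measured compounds shown here, the only step available, a number 0.1 percentage points lower from compound 1 to compound 2 (within the scatter), swaps the aryl group on the same oxygen and stays within the scatter, and compound 3, which also carries a 4-methoxyphenoxy group, sits within the scatter of compound 2. On this basis no step beyond the scatter is expected. The estimated step is a number 0.6 percentage points higher from compound 2 to compound 4 (within the scatter). Compound 4 is therefore expected to give about 3%, with a range of 0.5% to 7%.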

Compound 4, a percentage reported as activity, at one concentration (the size of the read-out at that concentration, not a potency): 59.4%
For compound 4 the middle estimate is 56.4 percentage points below the measured one, outside the stated range (above it).
By their numbers in this assay, from the lowest: compounds 2, 1 and 3 (each within the scatter of the next); then compound 4.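

In this assay the aryl group on an oxygen on a saturated carbon proves able to move the read-out far: 4-methoxyphenyl in place of 2-methylphenyl brings a number 57 percentage points higher from compound 2 to compound 4 (beyond the scatter) and in place of naphthalen-2-yl brings a number 56.9 percentage points higher from compound 1 to compound 4 (beyond the scatter) whereas the earlier exchange at this place gave only a number 0.1 percentage points lower from compound 1 to compound 2 (within the scatter) in the same read-out. The 4-methoxyphenoxy group alone does not go with a high number, however: compound 3 also carries it and gives 3.1% in this read-out. Nothing measured here accounts for the jump.

Open, as far as these compounds go, is whether 4-hydroxyphenyl or 4-aminophenyl on the same oxygen would hold this high number, and whether a longer chain in place of the saturated carbon would. Also open, from the compounds shown here alone, is how the read-out behaves at other concentrations, since each number stands at a single one.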